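Cyclohexyl ester amides: methyl to bromo on the aryl ester

The source may hold more compounds than are shown below. What is called first, only, known or untested is meant among the compounds shown, and "the series" means these compounds.

Measured so far in a functional assay on HepG2 cells (Homo sapiens) for inhibition, read by MTT assay, with a stated time of 72 h; on this read-out lower numbers stand for stronger inhibition and higher numbers for weaker inhibition:
- compound 1 `O=C(OC1(C(=O)Nc2ccc([N+](=O)[O-])cc2)CCCCC1)c1ccc(C(F)(F)F)cc1`: 29.1 nM
- compound 2 `Cc1ccc(C(=O)OC2(C(=O)Nc3ccc([N+](=O)[O-])cc3)CCCCC2)cc1`: 61.2 nM

Compound 2 stands at the higher of the two numbers in this assay; its nearest neighbour is compound 1, and a 2.1-fold higher number from compound 1 to compound 2 (0.32 log units; beyond the scatter) separates them, a modest step beyond the scatter.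

The next compound, compound 3 `O=C(OC1(C(=O)Nc2ccc([N+](=O)[O-])cc2)CCCCC1)c1ccc(Br)cc1`, differs from compound 2 in one place: bromo in place of methyl on an aromatic carbon. The change sits on an aromatic carbon of the benzoate ring, para to a large group, the same position where compound 1 carries trifluoromethyl and compound 2 carries methyl.

For the measured compounds named here, no measured step covers a bromo substituent. Going by the values given here, the only step available, a 2.1-fold higher number from compound 1 to compound 2 (0.32 log units; beyond the scatter), shows that exchanging the group at this position moves the number by a modest amount and no more. A step of similar size is therefore expected for compound 3, with the direction uncertain; the estimate is placed between the two measured values, a little nearer compound 2, and the expected step is a 1.5-fold lower number from compound 2 to compound 3 (0.16 log units; within the scatter).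

For compound 3 in this assay the expected value is 42 nM, with a range from 15 nM to 120 nM.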

Compound 3, half-maximal inhibitory concentration: 284 nM
The estimate for compound 3 lay 6.8-fold (0.83 log units) below the measured number; the measured number lies above the stated range.
By their numbers in this assay, from the lowest: compound 1; then compound 2; then compound 3.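

In this assay, for the compounds shown here, this position proves more sensitive to its substituent than the earlier pair indicated: bromo in place of methyl gives a 4.6-fold higher number from compound 2 to compound 3 (0.67 log units; beyond the scatter) and so exceeds the only earlier step, a 2.1-fold higher number from compound 1 to compound 2 (0.32 log units; beyond the scatter) for methyl in place of trifluoromethyl. Bromo in place of trifluoromethyl gives a 9.8-fold higher number from compound 1 to compound 3 (0.99 log units; beyond the scatter) as the widest spread so far, which puts the three compounds in the order trifluoromethyl, methyl, bromo from lowest to highest number. Methyl and bromo each count one heavy atom, with no hydrogen-bond donors or acceptors and no net charge, so these counts do not separate the two groups, and no measurement on hand bears on why the number moves as it does.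

Still open, as far as these compounds go, is whether the order extends to other groups on this aromatic carbon, such as chloro, fluoro, methoxy or an amine, and whether bromo stays at the high end among them. Also open, from the compounds shown here alone, is whether the same steps hold when the rest of the shared core changes, for instance with a nitrile in place of the nitro group.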